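The source may report more compounds than this note shows. Statements on the series, on what has been measured and on what is new or still open speak of the compounds shown alone.

Within the data shown here, in an ADME assay on microsomes from liver (Mus musculus) for metabolic stability (a lower number here means that the compound disappears faster, a higher number that the compound lasts longer), compound 3 (`CC(C)C(Nc1nnc[nH]1)c1ccc(-c2ccc3cccc(F)c3c2)[nH]c1=O`) gives 2.42 h, the highest of the three numbers so far. Compound 1 (`CCC(CC)(c1nnc[nH]1)c1ccc(-c2ccc3cc(F)cc(F)c3c2)[nH]c1=O`) gives 1.09 h, and compound 2 (`CC(C)C(c1ccc(-c2ccc3cccc(F)c3c2)[nH]c1=O)N1CCCCS1(=O)=O`) gives 0.0733 h. Compound 4 (`CC(C)C(Cc1nnc[nH]1)c1ccc(-c2ccc3cccc(F)c3c2)[nH]c1=O`) carries (4H-1,2,4-triazol-3-yl)methyl in place of (4H-1,2,4-triazol-3-yl)amino on a saturated chain carbon bound to an aromatic carbon and a saturated chain carbon. Among the measured compounds shown here, the only measured step at this place is a 33-fold higher number from compound 2 to compound 3 (1.52 log units; beyond the scatter). It is large, but it exchanged a six-membered non-aromatic ring for the five-membered aromatic ring, and that aromatic ring stays here. Compound 1 also holds this aromatic ring, without the amino link, and gives 1.09 h, though it differs in other places too. In this assay no shift beyond the scatter is expected, the estimated step being a 1.3-fold lower number from compound 3 to compound 4 (0.13 log units; within the scatter). Compound 4 is expected at 1.8 h, with an estimated range of 0.7 h to 4.5 h.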

Compound 4, half-life: < 0.0667 h
Compound 4 was reported as a limit; the forecaster's own chance of this, stated with the estimate: 5%; at least 26-fold (1.43 log units) between middle value and limit.
By their numbers in this assay, from the lowest: compound 2; then compound 1; then compound 3. At a limit, below all of these: compound 4.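

In this assay compound 4 is reported only as a limit: the limit of < 0.0667 h in this assay, at which 1 of the 4 values shown sits. With the five-membered aromatic ring kept, (4H-1,2,4-triazol-3-yl)methyl in place of (4H-1,2,4-triazol-3-yl)amino on a saturated chain carbon bound to an aromatic carbon and a saturated chain carbon gives a large step, an at least 36-fold lower number from compound 3 to compound 4 (1.55 log units; beyond the scatter), so this ring alone does not secure the number seen for compound 3. A further step, an at least 1.0-fold lower number from compound 2 to compound 4 (0.04 log units; that floor lies within the scatter), cannot be read: its floor lies within the scatter.

Open, from the compounds shown here alone, is whether an ether oxygen or a methylated amine in place of the amino link would stay nearer compound 3 or compound 4. Also open, going by these compounds, is whether the same exchange gives a similar step on the core of compound 1.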